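Ethoxy in place of methyl on the anilino ring

The compounds below may be only part of what the source reports. "The series", "measured", "known", "first", "only" and "open" are said of these compounds alone.

Working notes on the series. Compound 3 `Cc1cccc(Nc2nc3nonc3nc2Nc2ccccc2F)c1` gives 1500 nM in an assay on mitochondria from L6 cells (Rattus norvegicus) for activation, with a stated time of 90 min; on this read-out lower numbers stand for an effect already at smaller amounts and higher numbers for an effect only at larger amounts of compound. Among the three numbers on hand it stands second highest: compound 1 `Cc1cccc(Nc2nc3nonc3nc2Nc2cccc(C)c2)c1` gives 2100 nM, and compound 2 `Fc1cccc(Nc2nc3nonc3nc2Nc2ccccc2F)c1` gives 190 nM. The step of a 1.4-fold lower number from compound 1 to compound 3 (0.15 log units; within the scatter) stays within the scatter, whereas the step of a 7.9-fold higher number from compound 2 to compound 3 (0.90 log units; beyond the scatter) lies beyond it.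

Compound 4 `CCOc1ccc(Nc2nc3nonc3nc2Nc2ccccc2F)cc1` is not yet measured. Compared with compound 3 the change is 4-ethoxyphenyl in place of 3-methylphenyl on a nitrogen on an aromatic ring. Within the data shown here, none of the measured steps alters the same group in the same way: the step from compound 1 to compound 3 touches the other nitrogen, and the step from compound 2 to compound 3 swaps methyl for fluoro on this ring but says nothing about ethoxy. Among the measured compounds shown here, the one informative step, the modest one from compound 2 to compound 3, shows that the substituent on this ring can move the number beyond the scatter, but its direction for ethoxy cannot be read from it. No step beyond the scatter is therefore expected for a 1.2-fold lower number from compound 3 to compound 4 (0.06 log units; within the scatter), with a wide range kept on either side. Compound 4 is estimated at 1300 nM in this assay, between 400 nM and 4500 nM.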

Compound 4, half-maximal effective concentration: 3800 nM
Compound 4: middle estimate off by 2.9-fold (0.47 log units), on the low side, within the range that was stated.
By their numbers in this assay, from the lowest: compound 2; then compounds 3, 1 and 4 (each within the scatter of the next, the first and the last beyond it).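

In this assay, 4-ethoxyphenyl in place of 3-methylphenyl on this nitrogen gives a 2.5-fold higher number from compound 3 to compound 4 (0.40 log units; beyond the scatter) and so moves the number upward, the first sign here that an oxygen-bearing group on this ring does not restore the lower number of compound 2. Against 3-fluorophenyl, the same 4-ethoxyphenyl gives a 20-fold higher number from compound 2 to compound 4 (1.30 log units; beyond the scatter), a large step that widens the spread at this position beyond what the 3-methylphenyl comparison showed. Nothing measured gives a reason for either step.

The change alters both the group and its place on the ring, so 3-ethoxyphenyl and 4-methylphenyl would be needed to separate the two. On these data alone, how an amine, a carboxylic acid or a longer alkoxy chain on this ring would read remains open.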